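The compounds below may be only part of what the source reports. "The series", "measured", "known", "first", "only" and "open" are said of these compounds alone.

Of the compounds shown here, three built on the shared core have been measured in a functional assay on PC-3 cells (Homo sapiens) for inhibition, read by MTT assay, with a stated time of 48 h; on this read-out higher numbers stand for weaker inhibition and lower numbers for stronger inhibition. There, compound 1 (`COc1ccc(-c2coc3cc(OCCCCSC(=S)N4CCN(C(=O)OC(C)(C)C)CC4)ccc3c2=O)cc1`) gives 4610 nM, compound 2 (`COc1ccc(-c2coc3cc(OCCCSC(=S)N4CCN(C)CC4)ccc3c2=O)cc1`) gives 2210 nM, and compound 3 (`COc1ccc(-c2coc3cc(OCCCSC(=S)N4CCN(Cc5ccccc5)CC4)ccc3c2=O)cc1`) gives 14900 nM. That last value is the highest of the three, so compound 3 is the weakest inhibitor so far.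

Compound 4 (`COc1ccc(-c2coc3cc(OCCCSC(=S)N4CCN(c5ccccn5)CC4)ccc3c2=O)cc1`) has not yet been measured. It differs from compound 3 in one place, with pyridin-2-yl in place of benzyl on an amine nitrogen in a ring.

Among the measured compounds shown here, only one measured step involves that same nitrogen: a 6.7-fold higher number from compound 2 to compound 3 (0.83 log units; beyond the scatter). This step is modest but beyond the scatter, and it shows that the group held there can move the number. Compound 1 differs from compound 3 in more than one place, so it offers only loose guidance. For the measured compounds named here, no measurement yet shows how a pyridin-2-yl group behaves at this nitrogen.

The expectation is therefore a partial return towards the lower values, smaller than the step seen from the measured pair. The expected change is a 2.3-fold lower number from compound 3 to compound 4 (0.36 log units; beyond the scatter), and it is an uncertain one. For compound 4, the estimated value is 6500 nM, with an expected range of 2200 nM to 16000 nM.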

Compound 4, half-maximal inhibitory concentration: 17400 nM
For compound 4 the middle estimate is 2.7-fold (0.43 log units) below the measured one; measured number above the stated range.
By their numbers in this assay, from the lowest: compound 2; then compound 1; then compounds 3 and 4 (each within the scatter of the next).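

In this assay, replacing benzyl with pyridin-2-yl on the amine nitrogen in the ring gives a 1.2-fold higher number from compound 3 to compound 4 (0.07 log units; within the scatter), so removing a carbon-only aromatic ring and adding one with a hetero atom and a hydrogen-bond acceptor leaves the number within the scatter. Against the methyl group at the same nitrogen, pyridin-2-yl gives a 7.9-fold higher number from compound 2 to compound 4 (0.90 log units; beyond the scatter), and benzyl gives a 6.7-fold higher number from compound 2 to compound 3 (0.83 log units; beyond the scatter), so among these three compounds, which share the same chain, both groups containing an aromatic ring give clearly higher numbers than methyl, and none of the three goes against this. No evidence is available that explains these numbers.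

Benzyl and pyridin-2-yl differ both in the carbon that links benzyl to the nitrogen and in the hetero atom of the ring, so a phenyl group at this nitrogen would be needed to separate those two differences. On these data alone, it also remains open whether a plain hydrogen or an ethyl group at this nitrogen would stay close to compound 2, at 2210 nM, or move towards the higher numbers.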